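A Ring in Place of a Branched Chain

The compounds below may be only part of what the source reports. "The series", "measured", "known", "first", "only" and "open" are said of these compounds alone.

Compound 1, `CCCCCn1nc(C(=O)N[C@H]2COc3ccccc3N(C)C2=S)nc1Cc1ccccc1`: 805 nM
Compound 2, `CC(C)CCn1nc(C(=O)N[C@H]2COc3ccccc3N(C)C2=S)nc1Cc1ccccc1`: 3640 nM

Both numbers come from a functional assay on HT-29 cells (Homo sapiens) for inhibition, read by luminescence and CellTiter-Glo, with a stated time of 24 h; on this read-out lower numbers stand for an effect already at smaller amounts and higher numbers for an effect only at larger amounts of compound. Among the measured compounds shown here, of the two, compound 2 gives the higher number, and the only measured step, a 4.5-fold higher number from compound 1 to compound 2 (0.66 log units; beyond the scatter), is beyond the scatter. Compound 3, `CN1C(=S)[C@@H](NC(=O)c2nc(Cc3ccccc3)n(CC3CCOCC3)n2)COc2ccccc21`, differs from compound 2 by oxan-4-yl in place of isobutyl on a saturated chain carbon bound to an aromatic nitrogen. For the measured compounds named here, no measured step covers this kind of change, so the one step recorded shows only that altering this chain can move the number a modest amount. Compound 3 is expected to give about 2500 nM, within 700 nM to 9000 nM, a step of a 1.5-fold lower number from compound 2 to compound 3 (0.16 log units; within the scatter) that is estimated, not known.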

Compound 3, half-maximal effective concentration: 6310 nM
The estimate for compound 3 lay 2.5-fold (0.40 log units) below the measured number, and the stated range covers the measured number.
By their numbers in this assay, from the lowest: compound 1; then compounds 2 and 3 (each within the scatter of the next).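

In this assay, oxan-4-yl on this saturated chain carbon cannot be told apart from isobutyl (a 1.7-fold higher number from compound 2 to compound 3 (0.24 log units; within the scatter)), so swapping the branched end for a six-membered ring containing oxygen shifts the number no more than repeat measurements would. The unbranched chain of compound 1 keeps a clear lead over this ring (a 7.8-fold higher number from compound 1 to compound 3 (0.89 log units; beyond the scatter)), as it does over the branched chain of compound 2. No available measurement offers a reason for these numbers.

Still open, going by these compounds, is how an amine or a carboxylic acid at this place would compare, and whether a longer straight chain would give a lower number than compound 1.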